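Swapping the side ring on a slowly cleared core

A few compounds are considered here, and "the series" means these few. Any claim that something is new, unique, unknown or untested is made for them only; others in the source may bear on it.

Compound 1 `CCOc1cc([C@](O)(CCN(C)C)[C@@H](c2cc3cc(Br)ccc3nc2OC)c2cccc(OC)c2F)cc(OC)n1` gives 4.1 uL/min in an ADME assay on microsomes from liver (Homo sapiens) for metabolic stability; a lower number here means slower removal, a higher number faster removal of the compound. Compound 2 `CCOc1cc([C@](O)(CCN(C)C)[C@@H](c2cc3cc(Br)ccc3nc2OC)c2ccnc(OC)c2OC)cc(OC)n1` gives 3.8 uL/min in this assay; the change 2,3-dimethoxypyridin-4-yl in place of 2-fluoro-3-methoxyphenyl on a saturated chain carbon bound to an aromatic carbon and a saturated chain carbon made a 1.1-fold lower number from compound 1 to compound 2 (0.03 log units; within the scatter). Compound 3 `COc1cc([C@](O)(CCN(C)C)[C@@H](c2cc3cc(Br)ccc3nc2OC)c2cccc(OC)c2F)cc(OC(F)F)n1` gives 0.1 uL/min in this assay; its core differs from the core of compound 1 by difluoromethyl in place of ethyl on an oxygen on an aromatic ring, and that change made a 41-fold lower number from compound 1 to compound 3 (1.61 log units; beyond the scatter). Compound 4 `COc1cc([C@](O)(CCN(C)C)[C@@H](c2cc3cc(Br)ccc3nc2OC)c2ccnc(OC)c2OC)cc(OC(F)F)n1` has not yet been measured. It differs from compound 3 by 2,3-dimethoxypyridin-4-yl in place of 2-fluoro-3-methoxyphenyl on a saturated chain carbon bound to an aromatic carbon and a saturated chain carbon, the same change as between compound 1 and compound 2, at the same place. Because that earlier change made a 1.1-fold lower number from compound 1 to compound 2 (0.03 log units; within the scatter), this change is expected to make no change at the digits printed from compound 3 to compound 4 (within the scatter). Compound 4 is therefore estimated at 0.1 uL/min, probably between 0.03 uL/min and 0.3 uL/min in this assay. That expectation rests on compound 3 giving 0.1 uL/min.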

Compound 4, intrinsic clearance in a liver preparation (reported as CLH), per the amount of preparation that the assay uses: 2.1 uL/min
The estimate for compound 4 lay 21-fold (1.32 log units) below the measured number, outside the stated range (above it).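

In this assay, 2,3-dimethoxypyridin-4-yl in place of 2-fluoro-3-methoxyphenyl made a 21-fold higher number from compound 3 to compound 4 (1.32 log units; beyond the scatter), so this change did not carry over from the core of compound 1 to the core of compound 3: the same change on two cores in this assay, a 1.1-fold lower number (0.03 log units; within the scatter) from compound 1 to compound 2 and a 21-fold higher number (1.32 log units; beyond the scatter) from compound 3 to compound 4, 23-fold (1.36 log units) apart, beyond the scatter of two such steps. Likewise, difluoromethyl in place of ethyl made a 1.8-fold lower number from compound 2 to compound 4 (0.26 log units; within the scatter), so its effect depends on which side ring is present: the same change on two cores in this assay, a 41-fold lower number (1.61 log units; beyond the scatter) from compound 1 to compound 3 and a 1.8-fold lower number (0.26 log units; within the scatter) from compound 2 to compound 4, 23-fold (1.36 log units) apart, beyond the scatter of two such steps. These four compounds show that the two changes do not simply add up here, but they do not show why, or how either change behaves on any other core.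

From the compounds shown here alone, it remains open how trifluoromethyl or methyl on that oxygen would fare with each side ring. Going by these compounds, whether a side ring carrying a nitrile would follow compound 3 or compound 4 also remains open.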